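Swapping piperidin-1-yl for azepan-1-yl on compound 3

The source may report more compounds than this note shows. Statements on the series, on what has been measured and on what is new or still open speak of the compounds shown alone.

Values measured so far in an ADME assay on microsomes from liver (Mus musculus) for metabolic stability (a higher number here means faster removal of the compound, a lower number slower removal), are these
- compound 1 `O=C(CCCN1CCCCCC1)Nc1nnc(-c2ccc(F)cc2)s1` gives < 1 mL.min-1.g-1 (a limit of the assay)
- compound 2 `O=C(CCCN1CCCCCC1)Nc1cnc(-c2ccc(F)cc2F)s1` gives 24 mL.min-1.g-1
- compound 3 `O=C(CCCN1CCCCC1)Nc1cnc(-c2ccc(F)cc2)s1` gives 14 mL.min-1.g-1

Compound 1 sits at a limit (< 1 mL.min-1.g-1) and not at a number. Going by the values given here, that leaves compound 2 and compound 3 as the only true numbers, and the two lie within the scatter of each other, so compound 3 stands level with compound 2 as far as this assay can tell.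

Compound 4 `O=C(CCCN1CCCCCC1)Nc1cnc(-c2ccc(F)cc2)s1` has not yet been measured. It differs from compound 3 in one place (azepan-1-yl in place of piperidin-1-yl on a saturated chain carbon, three bonds along the chain from a carbonyl carbon) with azepan-1-yl in place of piperidin-1-yl on a saturated chain carbon, three bonds along the chain from a carbonyl carbon.

Among the compounds with values here, no measured pair shows this change on its own, so any expectation is indirect. Compound 2 gives 24 mL.min-1.g-1 with the same azepan-1-yl group, though it differs from compound 4 elsewhere. Compound 1 also carries azepan-1-yl, but on a different core, and offers little guidance.

The expected change is a 1.4-fold higher number from compound 3 to compound 4 (0.15 log units; within the scatter) and is estimated to be small, quite possibly no larger than the scatter. Compound 4 is expected at 20 mL.min-1.g-1 (estimated range 9 mL.min-1.g-1 to 42 mL.min-1.g-1).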

Compound 4, intrinsic clearance in microsomes in the Mus musculus assay: 18 mL.min-1.g-1
For compound 4 the middle estimate is 1.1-fold (0.05 log units) above the measured one; the range from low to high includes it.
By their numbers in the Mus musculus assay, from the lowest: compounds 3, 4 and 2 (each within the scatter of the next). At a limit, below all of these: compound 1.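

Going by these compounds alone, this is the first pair in which azepan-1-yl replaces piperidin-1-yl with nothing else changing, on a saturated chain carbon, three bonds along the chain from a carbonyl carbon, and in the Mus musculus assay compound 3 gives 14 mL.min-1.g-1 and compound 4 gives 18 mL.min-1.g-1 and the step is a 1.3-fold higher number from compound 3 to compound 4 (0.11 log units; within the scatter) so the seven-membered ring and the six-membered ring stand level in this assay. The fluoro position now has a clean pair too, and hydrogen in place of fluoro on an aromatic carbon gives a 1.3-fold lower number from compound 2 to compound 4 (0.12 log units; within the scatter) so that difference cannot be told from repeat-to-repeat variation either. The ring swap also leaves a physicochemical assay for lipophilicity, read by LC-MS, measured as octanol-water partition, with a stated time of 18 h, at pH 7.4 (a higher number here means a more lipophilic compound, a lower number a more polar compound), without a clear difference: compound 3 gives 1.81 and compound 4 gives 1.93 with a number 0.12 log units higher from compound 3 to compound 4 (within the scatter) as the step, which means that at this position neither assay separates the two rings.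

The compounds shown cover only these two rings at this place, so it stays open whether a morpholine ring, an open-chain amine such as dimethylamino or a longer chain would move these numbers beyond the scatter. Nothing shown here accounts for the size of these steps.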